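The source may report more compounds than this note shows. Statements on the series, on what has been measured and on what is new or still open speak of the compounds shown alone.

Measured so far in a functional assay on LNCaP cells (Homo sapiens) for cytotoxicity, read by sulforhodamine B assay, with a stated time of 48 h; on this read-out higher numbers stand for weaker inhibition and lower numbers for stronger inhibition:
Compound 1 `O=[N+]([O-])c1ccc(-c2nccn2S(=O)(=O)c2ccccc2)cc1`: > 10000 nM, a limit.
Compound 2 `O=S(=O)(c1ccccc1)n1ccnc1-c1ccc(OCc2ccccc2)cc1`: > 10000 nM, a limit.

Compound 2 stands only at a limit, and no number exists for it. Going by the values given here, the series so far offers just this: the limit of > 10000 nM in this assay, at which 2 of the 2 values shown sit.

The next compound to be measured is compound 3 `O=S(=O)(c1ccccc1)n1ccnc1-c1ccccc1`, which carries hydrogen in place of benzyloxy on an aromatic carbon.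

Among the compounds with values here, the one measured step that bears on this change also replaces a group on an aromatic carbon: a step that the two limits leave unreadable from compound 1 to compound 2. Its size cannot be read, so it hands on neither a size nor a direction. For compound 3 a limit is again the likeliest outcome in this assay, with no step beyond the scatter expected and no direction foreseen, because of the limit of > 10000 nM in this assay, at which 2 of the 2 values shown sit. The estimated step that the limit leaves unreadable from compound 2 to compound 3 is therefore only nominal. For compound 3 the expected value is 15000 nM, with an estimated range from 6000 nM to 40000 nM.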

Compound 3, half-maximal inhibitory concentration: > 10000 nM
Compound 3: no number, only a limit; the forecaster's own chance of this, stated with the estimate: 85%; the middle value is on the limit's open side.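

No step among compound 1, compound 2 and compound 3 can be read in this assay, since each stands only at a limit: the limit of > 10000 nM in this assay, at which 3 of the 3 values shown sit.

The compounds shown leave open whether nitro, benzyloxy or hydrogen on this aromatic carbon of the shared core differ at all in this read-out, and in which direction.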